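Swapping the thiadiazole for a phenyltetrazole on the sulfur

The compounds below may be only part of what the source reports. "The series", "measured", "known", "first", "only" and "open" are said of these compounds alone.

Measured so far:
compound 1 `Cc1nnc(SCC(=O)N/N=c2/scc(-c3ccccc3)n2-c2ccccc2)s1`, 61.8%
compound 2 `Cc1nnc(SCC(=O)N/N=c2/scc(-c3ccc(F)cc3)n2-c2ccccc2)s1`, 34.9%
compound 3 `Cc1nnc(SCC(=O)N/N=c2/scc(-c3ccc(Cl)cc3)n2-c2ccccc2)s1`, 34.1%

All three were tested in a functional assay on C6 cells (Rattus norvegicus) for cytotoxicity, read by MTT assay, with a stated time of 24 h, tested at 100 ug/mL; on this read-out lower numbers stand for a stronger effect and higher numbers for a weaker effect at the one concentration tested. Compound 2 stands second highest of the three numbers. Its nearest neighbour is compound 3, and the pair is a number 0.8 percentage points lower from compound 2 to compound 3 (within the scatter), so nothing separates them. The furthest is compound 1, where the step is a number 26.9 percentage points lower from compound 1 to compound 2 (beyond the scatter); the parallel step is a number 27.7 percentage points lower from compound 1 to compound 3 (beyond the scatter). Both of these steps change only the halogen on the aromatic carbon.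

The next compound, compound 4 `O=C(CSc1nnnn1-c1ccccc1)N/N=c1/scc(-c2ccc(F)cc2)n1-c1ccccc1`, differs from compound 2 elsewhere: 1-phenyl-1H-tetrazol-5-yl in place of 5-methyl-1,3,4-thiadiazol-2-yl on a sulfur. Among the compounds with values here, no measured step touches the group on the sulfur, so there is no direct precedent for this change. The fluoro that set compound 2 apart from compound 1 is kept. What remains is the fact that compound 2 and compound 3 share their number, which says nothing about the sulfur group either.

With no guide in either direction, compound 4 is expected to stay close to compound 2, an expected step of a number 3.1 percentage points higher from compound 2 to compound 4 (within the scatter), with a wide margin for the unknown. The estimate for compound 4 is therefore 38%, within 18% to 62%.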

Compound 4, a percentage reported as activity, at one concentration (the size of the read-out at that concentration, not a potency): 35.8%
The estimate for compound 4 lay 2.2 percentage points above the measured number; the measured number falls inside the stated range.
By their numbers in this assay, from the lowest: compounds 3, 2 and 4 (each within the scatter of the next); then compound 1.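

This is the first step shown at the group on the sulfur, and in this assay the swap gives a number 0.9 percentage points higher from compound 2 to compound 4 (within the scatter), so compound 2 and compound 4 cannot be told apart on this read-out. The earlier compounds shown here showed only that the halogen on the aromatic carbon matters; this pair adds that, with the fluoro kept, the place on the sulfur accepts a 1-phenyl-1H-tetrazol-5-yl with 11 heavy atoms in place of a 5-methyl-1,3,4-thiadiazol-2-yl with 6, including an extra six-membered aromatic ring, and the number stays within the scatter. No measurement on hand explains why these two different groups read alike.

This single pair does not show whether the same swap would read alike with the hydrogen of compound 1 or the chloro of compound 3 in place of the fluoro, and a single concentration says nothing about potency. It also leaves open how this place on the sulfur would respond to a very different group, such as a carboxylic acid or an amine on a longer chain.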